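The source may report more compounds than this note shows. Statements on the series, on what has been measured and on what is new or still open speak of the compounds shown alone.

Measured compounds in an assay on cells for inhibition of Palmitoleoyl-protein carboxylesterase NOTUM variant C330S (Homo sapiens), read by fluorescence, with a stated time of 40 min; a lower number here means a stronger inhibitor, a higher number a weaker inhibitor:
compound 1, `Cc1cc(C(=O)O)c(C)n1-c1ccc(Cl)c(C(F)(F)F)c1`, gives 2100 nM;
compound 2, `Cc1cc(C(=O)O)c(C)n1-c1ccc(Cl)cc1`, gives 860 nM;
compound 3, `Cc1c(C(=O)O)ccn1Cc1ccccc1`, gives 3100 nM.

Compound 2 and compound 3 differ in more than one place; how the two cores differ is not broken down here. Between compound 2 and compound 1 there is one step, a 2.4-fold higher number from compound 2 to compound 1 (0.39 log units; beyond the scatter); the change is trifluoromethyl in place of hydrogen on an aromatic carbon. Compound 4, `Cc1c(C(=O)O)cc(C(F)(F)F)n1Cc1ccccc1`, is not yet measured. It stands to compound 3 as compound 1 stands to compound 2: trifluoromethyl in place of hydrogen on an aromatic carbon. This is the same kind of change, not the same change: in compound 1 the entering group sits on a six-membered aromatic ring of carbon only, ortho to a chloro group and meta to a large group, whereas in compound 4 it sits on a five-membered aromatic ring with 1 nitrogen, next to the ring nitrogen, next to the ring atom that bears a group of 7 heavy atoms, two ring bonds from the ring atom that bears a carboxy group and two ring bonds from the ring atom that bears a methyl group. Going by the values given here, only one earlier instance of this kind of change is known here, on a different core; the expectation is correspondingly loose. The step from compound 3 to compound 4 is expected to be a 2.1-fold higher number from compound 3 to compound 4 (0.32 log units; beyond the scatter), resting on the earlier pair with a 2.4-fold higher number from compound 2 to compound 1 (0.39 log units; beyond the scatter). Compound 4 is therefore estimated at 6500 nM, with a range from 2500 nM to 16000 nM.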

Compound 4, half-maximal inhibitory concentration: > 100000 nM
Compound 4: a limit, no number; the forecaster's own chance of this, stated with the estimate: 15%; middle value at least 15-fold (1.18 log units) from the limit.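

In this assay compound 4 gives > 100000 nM, which is a limit of the assay and not a number: the limit of > 100000 nM in this assay, at which 1 of the 4 values shown sits. Trifluoromethyl in place of hydrogen on an aromatic carbon gives an at least 32-fold higher number from compound 3 to compound 4 (1.50 log units; beyond the scatter), so in these two pairs the direction of the step carries from one core to the other but its size does not: the same change on two cores in this assay, a 2.4-fold higher number (0.39 log units; beyond the scatter) from compound 2 to compound 1 and an at least 32-fold higher number (1.50 log units; beyond the scatter) from compound 3 to compound 4, at least 13-fold (1.12 log units) apart, beyond the scatter of two such steps. The limit leaves the full size of the new step unknown, and two pairs, with the entering group in different surroundings, cannot show which difference between the cores separates the steps or predict the step on a further core.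

The compounds shown leave open whether a nitrile or a primary amide on that same aromatic carbon of the five-membered ring of compound 3 would give a measurable number in this assay. They also leave open what trifluoromethyl does on the six-membered aromatic ring of compound 3, the kind of ring that carries it in compound 1.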